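Chloroacyl urea to chloroalkyl amide: a repeated exchange

The source may report more compounds than this note shows. Statements on the series, on what has been measured and on what is new or still open speak of the compounds shown alone.

Working notes on a small antiproliferative series measured in a functional assay on HT-29 cells (Homo sapiens) for antiproliferative activity, with a stated time of 48 h; a lower number here means a stronger inhibitor, a higher number a weaker inhibitor.

Compound 1 `CC(C)(C)c1ccc(CNC(=O)NC(=O)CCl)cc1` gives 7100 nM in this assay. Compound 3 `CC(C)(C)c1ccc(CNC(=O)CCCCl)cc1` gives 72000 nM. Between them the single change is 3-chloropropyl in place of ((chloromethyl)carbonyl)amino on a carbonyl carbon, and the step is a 10-fold higher number from compound 1 to compound 3 (1.01 log units; beyond the scatter), a large loss of potency that is well outside the usual scatter.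

Compound 2 `CCCCCc1cccc(NC(=O)NC(=O)CCl)c1` carries a different core; the difference between the core of compound 1 and the core of compound 2 is not broken down here. In this assay compound 2 gives 8400 nM. The values of compound 1 and compound 2 lie within the scatter of each other, so no order between them is asserted.

Compound 4 `CCCCCc1cccc(NC(=O)CCCCl)c1` has not yet been measured in this assay. For the measured compounds named here, it is related to compound 2 by 3-chloropropyl in place of ((chloromethyl)carbonyl)amino on a carbonyl carbon, which is the same change, at the same kind of position, as the one seen from compound 1 to compound 3. The change has been observed only once so far, so the expectation rests on a single precedent.

The step from compound 2 to compound 4 is expected to be about a 10-fold higher number from compound 2 to compound 4 (1.00 log units; beyond the scatter), taken directly from the step from compound 1 to compound 3 of a 10-fold higher number from compound 1 to compound 3 (1.01 log units; beyond the scatter). On that basis compound 4 is expected to give roughly 84000 nM in this assay, with a plausible range from 30000 nM to 220000 nM.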

Compound 4, half-maximal inhibitory concentration: > 100000 nM
Compound 4: only a limit was reported; the forecaster's own chance of this, stated with the estimate: 25%; at least 1.1-fold (0.07 log units) between middle value and limit.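

In this assay compound 4 gives > 100000 nM, which is a limit of the assay and not a number. Putting 3-chloropropyl in place of ((chloromethyl)carbonyl)amino on a carbonyl carbon again goes with a large loss of potency, with an at least 11-fold higher number from compound 2 to compound 4 (1.07 log units; beyond the scatter), so on the two cores shown the step runs the same way and is large both times: the same change on two cores in this assay, a 10-fold higher number (1.01 log units; beyond the scatter) from compound 1 to compound 3 and an at least 11-fold higher number (1.07 log units; beyond the scatter) from compound 2 to compound 4; the limit leaves it open whether they differ This does not give the true size of the second step, does not show that the two steps are equal, and says nothing about any core beyond these two: the limit of > 100000 nM in this assay, at which 1 of the 4 values shown sits.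

The exchange removes the amino nitrogen and the carbonyl of the ((chloromethyl)carbonyl)amino group together and alters the chlorine-bearing chain at the same time, so the compounds shown do not separate which of these parts goes with the loss of potency. Also open, from the compounds shown here alone, is how the series responds to a longer chain in place of 3-chloropropyl, to the same chain with an amine or a carboxylic acid in place of the chlorine, or to a bromine-bearing version of the ((chloromethyl)carbonyl)amino group.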